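Clearance in the pyrimidinone series: cyclopropylpiperazine analogue

This account rests on a few compounds, and the source may have more. Where it says the series, first, only, none or still open, it means among the compounds named here.

Compound 1 `CCN(CC)c1cc(OCc2cc(F)c(Oc3ccc(Cl)c(C(F)(F)F)c3)c(F)c2)nc(=O)n1C` is the reference point. In an ADME assay on S9 fraction from liver (Rattus norvegicus, strain Wistar) for metabolic stability, tested at 0.1 uM (a higher number here means faster removal of the compound, a lower number slower removal), compound 1 gives 41.9 mL/min/kg, the second highest of the three numbers in hand. Its nearest neighbour is compound 3 `Cn1c(N2CCC(F)(F)CC2)cc(OCc2cc(F)c(Oc3ccc(Cl)c(C(F)(F)F)c3)c(F)c2)nc1=O`, which gives 23.6 mL/min/kg in this assay, a separation that stays within the scatter. The furthest is compound 2 `CN1CCN(c2cc(OCc3cc(F)c(Oc4ccc(Cl)c(C(F)(F)F)c4)c(F)c3)nc(=O)n2C)CC1`, which gives 1140 mL/min/kg in this assay.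

The step from compound 1 to compound 4 `Cn1c(N2CCN(C3CC3)CC2)cc(OCc2cc(F)c(Oc3ccc(Cl)c(C(F)(F)F)c3)c(F)c2)nc1=O` is 4-cyclopropylpiperazin-1-yl in place of diethylamino on an aromatic carbon.

Of the measured steps, the one that bears most directly on this change is a 27-fold higher number from compound 1 to compound 2 (1.43 log units; beyond the scatter), since compound 2 also carries a piperazine on the same aromatic carbon. The step of a 1.8-fold lower number from compound 1 to compound 3 (0.25 log units; within the scatter) and the step of a 48-fold lower number from compound 2 to compound 3 (1.68 log units; beyond the scatter) show that the piperazine bearing a methyl group stands apart from both the diethylamino and the difluoropiperidinyl analogues. From the compounds shown here alone, on this basis a large rise beyond the scatter is expected for compound 4, a 9.5-fold higher number from compound 1 to compound 4 (0.98 log units; beyond the scatter), though the cyclopropyl group on the distal nitrogen is untested and the size is uncertain.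

Compound 4 is therefore estimated at 400 mL/min/kg in this assay, in the range 90 mL/min/kg to 1500 mL/min/kg.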

Compound 4, clearance: 13.7 mL/min/kg
Compound 4: middle estimate off by 29-fold (1.47 log units), on the high side, and the stated range ends above it.
By their numbers in this assay, from the lowest: compounds 4, 3 and 1 (each within the scatter of the next, the first and the last beyond it); then compound 2.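

In this assay, a piperazine on this aromatic carbon does not by itself bring fast removal: with only cyclopropyl in place of methyl on the amine nitrogen in the ring, the series shows an 83-fold lower number from compound 2 to compound 4 (1.92 log units; beyond the scatter). The substituent on that nitrogen can therefore reverse the direction of the change from diethylamino, which was a 27-fold higher number from compound 1 to compound 2 (1.43 log units; beyond the scatter) for 4-methylpiperazin-1-yl but is a 3.1-fold lower number from compound 1 to compound 4 (0.49 log units; beyond the scatter) for 4-cyclopropylpiperazin-1-yl. Compound 4 also sits with the difluoropiperidine analogue, with a 1.7-fold lower number from compound 3 to compound 4 (0.24 log units; within the scatter), so 4-cyclopropylpiperazin-1-yl and 4,4-difluoropiperidin-1-yl are not separated at this position, and the high number of compound 2 now stands as the single outlier among the four compounds.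

Nothing in hand accounts for so large a gap between the methyl and cyclopropyl groups on the same nitrogen. From the compounds shown here alone, it remains open where a piperazine with a free amine hydrogen, or one carrying an ethyl, isopropyl or acetyl group on that nitrogen, would fall between compound 2 and compound 4.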